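A few compounds are considered here, and "the series" means these few. Any claim that something is new, unique, unknown or untested is made for them only; others in the source may bear on it.

Measured compounds in a functional assay on CCRF-CEM cells (Homo sapiens) for cytotoxicity, with a stated time of 72 h; on this read-out higher numbers stand for weaker inhibition and lower numbers for stronger inhibition:

compound 1, `Cc1ccc(/C=C2\CCC/C(=C\c3cccc([N+](=O)[O-])c3)C2=O)cc1`: 10100 nM
compound 2, `COc1cc(/C=C2\CCC/C(=C\c3cccc([N+](=O)[O-])c3)C2=O)cc(OC)c1OC`: 45200 nM
compound 3, `COc1ccc(/C=C2\CCC/C(=C\c3ccccc3[N+](=O)[O-])C2=O)cc1`: 7450 nM

Compound 3 holds the lowest of the three numbers, but its gap to compound 1 lies within the usual scatter of this assay, so the two cannot be ordered against each other. Only compound 2 separates clearly: its number in this assay is higher than that of compound 3 by a margin beyond the scatter. The three compounds differ at more than one place, so no single change can be read out of these numbers.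

Compound 4, `O=C1/C(=C/c2ccc(Cl)cc2)CCC/C1=C\c1ccccc1[N+](=O)[O-]`, has not yet been measured. Its structure differs from compound 3 in one place: chloro in place of methoxy on an aromatic carbon. For the measured compounds named here, no measured pair in the set shows this exchange, so there is no step to lean on. The expectation is that the step from compound 3 to compound 4 stays small, with no clear direction beyond the scatter: a 1.1-fold lower number from compound 3 to compound 4 (0.03 log units; within the scatter). On these data alone, on that basis compound 4 is estimated at 7000 nM in this assay, with a range from 2500 nM to 20000 nM, the width reflecting that the exchange is untested here.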

Compound 4, half-maximal inhibitory concentration: 1750 nM
Beside the measured number, compound 4's estimate is 4.0-fold (0.60 log units) above it, outside the stated range (below it).
By their numbers in this assay, from the lowest: compound 4; then compounds 3 and 1 (each within the scatter of the next); then compound 2.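

In this assay, for the compounds shown here, the 4-methoxyphenyl to 4-chlorophenyl exchange gives a 4.3-fold lower number from compound 3 to compound 4 (0.63 log units; beyond the scatter), the only single-place step in the set, showing that the number responds to the group at this position when the rest of the structure is held constant. The change removes one hydrogen-bond acceptor and replaces a two-heavy-atom group with a one-heavy-atom group, but a single pair cannot show whether either difference matters. Nothing measured here accounts for the size or direction of the step.

On these data alone, whether this response extends to other groups at the same place remains open, for example fluoro, bromo, hydroxy or dimethylamino, any of which would show whether chloro is a special case or part of a broader trend. As far as these compounds go, it is also open whether the same exchange gives a similar step on the core of compound 1, whose nitro group sits at a different place, so the result currently applies only to the arrangement shared by the compounds in this pair.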